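Shortening the Side Chain on a Ring Nitrogen

The source may report more compounds than this note shows. Statements on the series, on what has been measured and on what is new or still open speak of the compounds shown alone.

Of the compounds shown here, two with a shared core have been measured in a functional assay on cells for positive allosteric modulation of G-protein coupled receptor 68 (Homo sapiens), read by a luciferase reporter and cAMP accumulation, with a stated time of 30 min, at pH 6.8 and pH 8.3, in the presence of a further agent that is not named here; a higher number here means a more potent compound, by a factor of ten per unit of this negative logarithm, a lower number a less potent compound. Compound 1 `Nc1nc(NCc2cccc(Cl)c2)nc(-c2ccccc2CO)n1` gives 4.97. Compound 2 `Cc1ccc(CNc2nc(N)nc(-c3ccccc3CO)n2)cc1` gives 4.38, the lowest of the two numbers. Going by the values given here, the only measured step is a number 0.59 log units lower from compound 1 to compound 2 (beyond the scatter), and it swaps one aromatic group for another on the saturated chain carbon while leaving that carbon in place. Compound 3 `Nc1nc(Nc2ccccc2)nc(-c2ccccc2CO)n1` is not yet measured; its difference from compound 2 is phenyl in place of 4-methylbenzyl on a nitrogen on an aromatic ring, so the saturated chain carbon that linked the aromatic group to the ring nitrogen is gone, and the methyl with it. Among the compounds with values here, no measured step touches this kind of change, so there is nothing firm to lean on. The expected step is a number 0.12 log units higher from compound 2 to compound 3 (within the scatter), with no clear direction and possibly none beyond the scatter. Compound 3 is estimated at 4.5, within a range from 3.9 to 5.2.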

Compound 3, negative logarithm of the antagonist equilibrium constant: 3.92
Compound 3: the middle estimate sits 0.58 log units above what was measured, and the stated range covers the measured number.
By their numbers in this assay, from the lowest: compound 3; then compound 2; then compound 1.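

Until now only the aromatic group on the saturated chain carbon had changed; here that carbon itself goes, leaving the phenyl directly on the nitrogen, and this assay gives a number 0.46 log units lower from compound 2 to compound 3 (beyond the scatter) for this change. The same change measured against the chlorine-bearing group gives a number 1.05 log units lower from compound 1 to compound 3 (beyond the scatter), so both compounds that keep the chain carbon stand beyond the scatter above compound 3, the lowest of the three. No measurement shown here accounts for this fall.

Compound 3 also lacks the methyl of compound 2 and the chlorine of compound 1, so the loss of the chain carbon cannot be separated from the loss of those substituents. An unsubstituted benzyl group would separate them, and a longer chain such as phenylethyl on the same nitrogen would show how the number responds when the link grows rather than shrinks.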